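Swapping the Benzyl Substituent on a Urea Acyl Series

The source may hold more compounds than are shown below. What is called first, only, known or untested is meant among the compounds shown, and "the series" means these compounds.

Three compounds share the same core and differ in the benzyloxy arm and in the urea link. Compound 1, `Cc1ccc(NC(=S)NC(=O)c2ccc(OCc3cccc(F)c3)cc2)cc1-c1nc2ccccc2[nH]1`, carries a thiourea and a fluoro group; in a functional assay on MNK45 cells (Homo sapiens) for inhibition, read by MTT assay, with a stated time of 48 h (on this read-out lower numbers stand for stronger inhibition and higher numbers for weaker inhibition), compound 1 gives 86800 nM. Compound 2, `Cc1ccc(NC(=O)NC(=O)c2ccc(OCc3cccc(Cl)c3)cc2)cc1-c1nc2ccccc2[nH]1`, has a urea and a chloro group, and in this assay compound 2 gives 28000 nM. Among the measured compounds shown here, compound 3, `Cc1ccc(NC(=O)NC(=O)c2ccc(OCc3cccc(C(F)(F)F)c3)cc2)cc1-c1nc2ccccc2[nH]1`, keeps the urea and carries trifluoromethyl; in this assay compound 3 gives 9600 nM, the lowest of the three numbers, and the step of a 2.9-fold lower number from compound 2 to compound 3 (0.46 log units; beyond the scatter) is the only single change measured here.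

Compound 4, `Cc1ccc(COc2ccc(C(=O)NC(=O)Nc3ccc(C)c(-c4nc5ccccc5[nH]4)c3)cc2)cc1`, makes a different change: 4-methylphenyl in place of 3-(trifluoromethyl)phenyl on a saturated chain carbon bound to an oxygen on an aromatic ring. For the measured compounds named here, no measured step covers this exact swap, so the only guide is that the one measured change on this same ring moved the number by a modest amount. Methyl is a smaller group in a different position than trifluoromethyl, and nothing measured here shows which way the number will move. The expectation is therefore a modest weakening, estimated as a 2.6-fold higher number from compound 3 to compound 4 (0.42 log units; beyond the scatter), leaving compound 4 at an expected 25000 nM with a range from 8000 nM to 80000 nM in this assay.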

Compound 4, half-maximal inhibitory concentration: 6360 nM
For compound 4 the middle estimate is 3.9-fold (0.59 log units) above the measured one; the whole stated range lies above it.
By their numbers in this assay, from the lowest: compounds 4 and 3 (each within the scatter of the next); then compound 2; then compound 1.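

In this assay, putting 4-methylphenyl in place of 3-(trifluoromethyl)phenyl on the saturated chain carbon bound to an oxygen on an aromatic ring gives a 1.5-fold lower number from compound 3 to compound 4 (0.18 log units; within the scatter), so this assay does not separate the two compounds. Compound 4 contains no fluorine, which shows that trifluoromethyl is not needed to reach this level among the compounds shown. The step against the chloro analogue, a 4.4-fold lower number from compound 2 to compound 4 (0.64 log units; beyond the scatter), places compound 2 clearly apart from compound 4, just as it stands apart from compound 3, and nothing shown here explains these numbers.

As far as these compounds go, the change from 3-(trifluoromethyl)phenyl to 4-methylphenyl alters both the group and its printed ring position at once, so the effect of each alone stays open, as does what a methoxy group, an amine or a carboxylic acid on this ring would do. Compound 1 differs from the others in both its thiourea link and its arm, so the effect of the thiourea on its own also remains unresolved.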